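Moving the methoxymethyl group: from compound 2 to compound 4

The compounds below may be only part of what the source reports. "The series", "measured", "known", "first", "only" and "open" are said of these compounds alone.

Compound 1 `COc1cc(C(c2ccc(O)c(OC)c2)[C@@H](C)[C@H](C)CO)ccc1O`: > 100000 nM
Compound 2 `COC[C@@H](C(C)C)C(c1ccc(O)c(OC)c1)c1ccc(O)c(OC)c1`: 69000 nM
Compound 3 `COC[C@H](C(C)C)C(c1ccc(O)c(OC)c1)c1ccc(O)c(OC)c1`: 76000 nM

Of the compounds shown here, three sharing one core have been tested in a functional assay on HeLa cells (Homo sapiens) for cytotoxicity, read by WST assay, with a stated time of 48 h; a higher number here means a weaker inhibitor, a lower number a stronger inhibitor. Compound 2 gives 69000 nM, the lowest of the two plain numbers, while compound 3 gives 76000 nM, a difference of a 1.1-fold higher number from compound 2 to compound 3 (0.04 log units; within the scatter), and these two are mirror partners, as the fact that compounds 2 and 3 differ only in the configuration as drawn shows. For compound 1 the assay reports only a limit, > 100000 nM, as stated in the limit of > 100000 nM in this assay, at which 1 of the 3 values shown sits. The step of an at least 1.4-fold lower number from compound 1 to compound 2 (0.16 log units; that floor lies within the scatter) and the step of an at least 1.3-fold lower number from compound 1 to compound 3 (0.11 log units; that floor lies within the scatter) are both floored by that limit.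

The unmeasured compound 4 `COC[C@@H](C)[C@H](C)C(c1ccc(O)c(OC)c1)c1ccc(O)c(OC)c1` differs from compound 2 by 2-(methoxymethyl)-1-methylpropyl in place of 1-(methoxymethyl)-2-methylpropyl on a saturated chain carbon bound to two aromatic carbons. This rearranged chain resembles the skeleton of compound 1, whose limit value bears on the outcome. For the measured compounds named here, no measured step separates two numbers beyond the scatter, so compound 4 is expected to remain weak, with an estimated step of a 1.3-fold higher number from compound 2 to compound 4 (0.12 log units; within the scatter) and a fair chance of a limit. The estimate for compound 4 is 90000 nM, within 45000 nM to 180000 nM.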

Compound 4, half-maximal inhibitory concentration: 58000 nM
Estimate against measurement, compound 4: 1.6-fold (0.19 log units) above; measured number inside the range.
By their numbers in this assay, from the lowest: compounds 4, 2 and 3 (each within the scatter of the next). At a limit, above all of these: compound 1.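

Rearranging the chain on the saturated chain carbon bound to two aromatic carbons, with 2-(methoxymethyl)-1-methylpropyl in place of 1-(methoxymethyl)-2-methylpropyl, gives a 1.2-fold lower number from compound 2 to compound 4 (0.08 log units; within the scatter) and a 1.3-fold lower number from compound 3 to compound 4 (0.12 log units; within the scatter), so in this assay a change in how the chain is joined, and not only in configuration, leaves these compounds indistinguishable. For the compounds shown here, compound 4 also forms the first single-place pair with compound 1, with methyl in place of hydrogen on an oxygen on a saturated carbon, giving an at least 1.7-fold lower number from compound 1 to compound 4 (0.23 log units; that floor lies within the scatter). That step is only a floor, and its size cannot be read: the limit of > 100000 nM in this assay, at which 1 of the 4 values shown sits.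

The compounds shown leave open whether any group at this place can separate values beyond the scatter. An amine or a carboxylic acid in place of the methoxy group, or a longer chain, might answer that.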